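The source may hold more compounds than are shown below. What is called first, only, known or untested is meant among the compounds shown, and "the series" means these compounds.

Measured so far in a functional assay on CCRF-CEM cells (Homo sapiens) for cytotoxicity; a higher number here means a weaker inhibitor, a lower number a stronger inhibitor: compound 1 `CC(=O)c1ccc(NC(=O)/C=C/C(=O)N2C/C(=C\c3ccccc3)C(=O)/C(=C/c3ccccc3)C2)cc1`, which gives 1700 nM; compound 2 `COc1ccc(NC(=O)/C=C/C(=O)N2C/C(=C\c3ccccc3)C(=O)/C(=C/c3ccccc3)C2)cc1`, which gives 510 nM.

Compound 2 stands lowest of the two numbers in this assay, and its nearest neighbour is compound 1, whose value is higher by the step of a 3.3-fold lower number from compound 1 to compound 2 (0.52 log units; beyond the scatter). The unmeasured compound 3 `O=C(/C=C/C(=O)N1C/C(=C\c2ccccc2)C(=O)/C(=C/c2ccccc2)C1)Nc1ccccc1` differs from compound 2 in one place: hydrogen in place of methoxy on an aromatic carbon. Among the compounds with values here, only one measured step bears on this change, the replacement of acetyl by methoxy at the same place, a 3.3-fold lower number from compound 1 to compound 2 (0.52 log units; beyond the scatter), which was modest though beyond the scatter. That step shows that the group at this position matters, but it does not say where hydrogen falls relative to methoxy. Compound 3 is therefore expected to land near compound 2 or somewhat higher, with the estimated step of a 1.8-fold higher number from compound 2 to compound 3 (0.25 log units; within the scatter). The estimate for compound 3 in this assay is 900 nM, within a range from 300 nM to 2500 nM.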

Compound 3, half-maximal inhibitory concentration: 1100 nM
The estimate for compound 3 lay 1.2-fold (0.09 log units) below the measured number; low and high end bracket the measured number.
By their numbers in this assay, from the lowest: compound 2; then compounds 3 and 1 (each within the scatter of the next).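

In this assay, hydrogen in place of methoxy on the aromatic carbon para to a large group gives a 2.2-fold higher number from compound 2 to compound 3 (0.33 log units; beyond the scatter), so the methoxy group itself sets compound 2 apart from the unsubstituted phenyl of compound 3. Hydrogen in place of acetyl gives a 1.5-fold lower number from compound 1 to compound 3 (0.19 log units; within the scatter), so 4-acetylphenyl and phenyl cannot be told apart in this assay. Of the three groups compared at this place, only methoxy stands apart, with both of its steps beyond the scatter. Nothing available gives a reason for this difference.

The compounds shown leave open whether methoxy is unique here or whether a hydroxyl, an amine or a longer ether such as ethoxy would give a similar number. They also leave open whether methoxy would have the same effect elsewhere on the ring.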